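This account rests on a few compounds, and the source may have more. Where it says the series, first, only, none or still open, it means among the compounds named here.

Compound 1 `C=CC(=O)Nc1cc(Nc2ncc(I)c(Nc3ccccc3S(=O)(=O)N(C)C)n2)c(OC)cc1N(C)CCN(C)C`: 12%
Compound 2 `C=CC(=O)Nc1cc(Nc2ncc(F)c(Nc3ccccc3S(=O)(=O)C(C)C)n2)c(OC)cc1N(C)CCN(C)C`: 15%

For the measured compounds named here, only two compounds have been measured so far in an ADME assay on microsomes from liver (Mus musculus) for metabolic stability, read by LC-MS, using NADPH, with a stated time of 30 min, tested at 1 uM; a lower number here means that less of the compound is left, a higher number that more of the compound is left. There, compound 2 gives 15% and compound 1 gives 12%, so the two numbers lie within the usual scatter of each other. Going by the values given here, neither can be said to outperform the other, and compound 2 stands level with the only available comparison.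

The next compound is compound 3 `C=CC(=O)Nc1cc(Nc2ncc(I)c(Nc3ccccc3S(=O)(=O)C(C)C)n2)c(OC)cc1N(C)CCN(C)C`, made from compound 2 by one change: iodo in place of fluoro on an aromatic carbon. Among the compounds with values here, no measured pair shows this change on its own, so its effect cannot be read directly from the data. The closest clue is compound 1, which also carries iodo and gives 12%. That is a single indirect comparison, so it offers no reason to expect a large move in either direction. The expected result is a number 2 percentage points lower from compound 2 to compound 3 (within the scatter), an estimated step that stays within the scatter. In this assay, compound 3 is expected to give 13%, with an estimated range from 5% to 25%.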

Compound 3, percent of the compound remaining: 10%
Beside the measured number, compound 3's estimate is 3 percentage points above it; measured number inside the range.
By their numbers in this assay, from the lowest: compounds 3, 1 and 2 (each within the scatter of the next).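

For the compounds shown here, with the result for compound 3, the swap of fluoro for iodo can be read on its own for the first time: in this assay the step is a number 5 percentage points lower from compound 2 to compound 3 (within the scatter) and so, on this aromatic carbon of the six-membered aromatic ring with 2 nitrogen, the two halogens cannot be told apart. Compound 3 also links compound 1 to the rest of the set. It shares the iodo group with compound 1 and differs only on the sulfonyl sulfur, where isopropyl in place of dimethylamino gives a number 2 percentage points lower from compound 1 to compound 3 (within the scatter) and again nothing stands clear of the usual scatter. Neither of these two single swaps, then, separates the compounds in this read-out, and no measurement at hand gives a reason for that.

What the compounds shown leave open is whether a group of another kind on that aromatic carbon, such as a nitrile or an amine, would give a number clearly apart in this assay. Going by these compounds, it is equally open whether a longer chain on the sulfonyl sulfur, or a change elsewhere on the shared core, would do so.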